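Compound 3 and Its Benzoxazole Analogue

The source may report more compounds than this note shows. Statements on the series, on what has been measured and on what is new or still open speak of the compounds shown alone.

The series is built on a shared core carried by compound 1 `O=C(O)CCCSCCN1C(=O)CC[C@@H]1/C=C/[C@@H](O)Cc1cccc(N2Cc3ccccc3C2)c1`, compound 2 `O=C(O)CCCSCCN1C(=O)CC[C@@H]1/C=C/[C@@H](O)Cc1cccc(-c2cc3ccccc3o2)c1` and compound 3 `O=C(O)c1csc(SCCN2C(=O)CC[C@@H]2/C=C/[C@@H](O)Cc2cccc(-c3ccc(Cl)cc3)c2)n1`, all three tested in an assay on CHO cells for displacement of a labelled ligand from prostaglandin E2 receptor EP3 subtype (Mus musculus), read by scintillation counting, with a stated time of 60 min; on this read-out lower numbers stand for stronger inhibition and higher numbers for weaker inhibition. In this assay compound 1 gives > 10000 nM, which is a limit of the assay and not a number. Compound 2 likewise reaches only a limit, > 10000 nM. Compound 3 too stops at a limit, > 10000 nM. Among the measured compounds shown here, the one pair that differs in a single place gives a step that the two limits leave unreadable from compound 1 to compound 2. Compound 3 thus stands at the limit of > 10000 nM in this assay, at which 3 of the 3 values shown sit, with nothing to set it apart from compound 1 or compound 2. Compound 4 `Cc1cccc2oc(-c3cccc(C[C@H](O)/C=C/[C@H]4CCC(=O)N4CCSc4nc(C(=O)O)cs4)c3)nc12` differs from compound 3 by 4-methyl-1,3-benzoxazol-2-yl in place of 4-chlorophenyl on an aromatic carbon. For the measured compounds named here, no measured step bears on this change: the only step available is unreadable and every value shown is a limit. For compound 4 a step that the limit leaves unreadable from compound 3 to compound 4 is therefore expected, which is to say no readable movement. The value of compound 4 in this assay is estimated at 20000 nM, within 5000 nM to 80000 nM.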

Compound 4, inhibition constant: > 10000 nM
Compound 4 gave a limit, no number; the forecaster's own chance of this, stated with the estimate: 80%; the middle value is on the limit's open side.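

Compound 3 and compound 4 both end at a limit of the assay and not a number, so no step between them can be read: the limit of > 10000 nM in this assay, at which 4 of the 4 values shown sit.

The compounds shown leave open how 4-methyl-1,3-benzoxazol-2-yl and 4-chlorophenyl compare, and whether any compound of this series gives a readable inhibition constant in this assay.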